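Chloro to trifluoromethyl at the limit of tolerance

A few compounds are considered here, and "the series" means these few. Any claim that something is new, unique, unknown or untested is made for them only; others in the source may bear on it.

Values in an ADME assay on MDCK cells (Canis lupus familiaris) for cytotoxicity, read by MTT assay, with a stated time of 24 h (a lower number here means that less compound is tolerated, a higher number that more compound is tolerated), are these:
compound 1 `N#CCCN(Cc1cccs1)S(=O)(=O)c1cccc(F)c1` gives > 205000 nM
compound 2 `N#CCCN(Cc1cccs1)S(=O)(=O)c1ccc(F)cc1` gives > 205000 nM
compound 3 `N#CCCN(Cc1cccs1)S(=O)(=O)c1ccc(Cl)cc1` gives > 195000 nM

Compound 3 gives > 195000 nM as a limit and not as a number, and the two other values are limits too. Compound 4 `N#CCCN(Cc1cccs1)S(=O)(=O)c1ccc(C(F)(F)F)cc1` carries trifluoromethyl in place of chloro on an aromatic carbon, para to a large group (trifluoromethyl in place of chloro on an aromatic carbon). The closest measured change is chloro in place of fluoro, and a step that the two limits leave unreadable from compound 2 to compound 3 gives no size to go on. The two other changes, a step that the two limits leave unreadable from compound 1 to compound 2 and a step that the two limits leave unreadable from compound 1 to compound 3 as well, offer none either. So no step beyond the scatter, in either direction, is expected in this assay for compound 4. The expected step runs (an at least 1.0-fold lower number from compound 3 to compound 4 (0.03 log units; that floor lies within the scatter)). Compound 4 is expected at 178000 nM (estimated range 130000 nM to 205000 nM).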

Compound 4, half-maximal cytotoxic concentration: > 178000 nM
Compound 4: a limit, no number; the forecaster's own chance of this, stated with the estimate: 90%; the middle value sits exactly at the limit.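

In this assay compound 4 gives > 178000 nM, a limit and not a number. Within the data shown here, no step from compound 2 or compound 3 to compound 4 can be read. The compounds shown leave open the concentration at which any of them becomes toxic to these cells.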